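Aryl variation on the benzylpiperazine amide series

A few compounds are considered here, and "the series" means these few. Any claim that something is new, unique, unknown or untested is made for them only; others in the source may bear on it.

Compound 3 `O=C(CN[C@H]1CCN(S(=O)(=O)Cc2ccccc2)C1)N1CCN(Cc2cccc(C(F)(F)F)c2)CC1` stands lowest of the three numbers measured in a functional assay on K562 cells (Homo sapiens) for cytotoxicity, read by MTT assay, with a stated time of 48 h (a lower number here means a stronger inhibitor, a higher number a weaker inhibitor), where compound 3 gives 3600 nM. Compound 1 `Cc1ccccc1CN1CCN(C(=O)CN[C@H]2CCN(S(=O)(=O)Cc3ccccc3)C2)CC1` gives 10200 nM and compound 2 `O=C(CN[C@H]1CCN(S(=O)(=O)Cc2ccccc2)C1)N1CCN(Cc2ccccc2F)CC1` gives 12600 nM. The step of a 1.2-fold higher number from compound 1 to compound 2 (0.09 log units; within the scatter) stays within the scatter, whereas a 2.8-fold lower number from compound 1 to compound 3 (0.45 log units; beyond the scatter) and a 3.5-fold lower number from compound 2 to compound 3 (0.54 log units; beyond the scatter) both go beyond it, so compound 3 is separated from the other two in this assay.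

Compound 4 `COc1ccc(CN2CCN(C(=O)CN[C@H]3CCN(S(=O)(=O)Cc4ccccc4)C3)CC2)cc1` keeps the shared core of compound 3 and differs in one place: 4-methoxyphenyl in place of 3-(trifluoromethyl)phenyl on a saturated chain carbon bound to an amine nitrogen in a ring.

Within the data shown here, no measured step introduces 4-methoxyphenyl, so the only guidance comes from the two aryl exchanges already seen, a 2.8-fold lower number from compound 1 to compound 3 (0.45 log units; beyond the scatter) and a 3.5-fold lower number from compound 2 to compound 3 (0.54 log units; beyond the scatter), which moved the number modestly when 3-(trifluoromethyl)phenyl entered. Taking that group out again is expected to give back part or all of that gain rather than extend it, so a modest rise toward the values of compound 1 and compound 2 is anticipated, with no change beyond the scatter remaining possible. Compound 4 is therefore estimated at 8000 nM, with a range from 3000 nM to 20000 nM. This estimate corresponds to an expected 2.2-fold higher number from compound 3 to compound 4 (0.35 log units; beyond the scatter).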

Compound 4, half-maximal inhibitory concentration: 50900 nM
For compound 4 the middle estimate is 6.4-fold (0.80 log units) below the measured one; the measured number lies above the stated range.
By their numbers in this assay, from the lowest: compound 3; then compounds 1 and 2 (each within the scatter of the next); then compound 4.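

In this assay, the group on a saturated chain carbon bound to an amine nitrogen in a ring can move the number much further than the first three compounds showed: a 14-fold higher number from compound 3 to compound 4 (1.15 log units; beyond the scatter) is a large step, whereas the earlier aryl exchanges were modest. The 4-methoxyphenyl group also separates compound 4 from the two remaining aryl compounds, with a 4.0-fold higher number from compound 2 to compound 4 (0.61 log units; beyond the scatter) and a 5.0-fold higher number from compound 1 to compound 4 (0.70 log units; beyond the scatter) both beyond the scatter, so this change does more than remove the gain seen with 3-(trifluoromethyl)phenyl and makes compound 4 the weakest of the four. No measurement available here bears on the reason for this rise.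

The 3-(trifluoromethyl)benzyl to 4-methoxybenzyl change replaces the substituent and alters its place on the aromatic ring in one step, so the compounds shown cannot separate these two contributions. An unsubstituted phenyl at this carbon would give a common reference for all four aryl groups, and a chlorine or nitrile on the ring would show whether the low number of compound 3 is specific to trifluoromethyl.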